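From 2-cyanocyclopropyl to 3-cyano-3-methylcyclobutyl: working notes

The source may report more compounds than this note shows. Statements on the series, on what has been measured and on what is new or still open speak of the compounds shown alone.

In an ADME assay on MDCKII-LE cells (Canis lupus familiaris) for permeability (a higher number here means that the compound crosses the layer faster, a lower number that the compound crosses the layer more slowly), compound 1 `NC(=O)[C@@H](CCC(F)(F)F)N(CC12CC(c3ncon3)(C1)C2)S(=O)(=O)c1ccc(Cl)cc1` stands at 19.3 10^-6 cm/s and compound 2 `N#CC12CC(CN([C@H](CCC(F)(F)F)C(N)=O)S(=O)(=O)c3ccc(Cl)cc3)(C1)C2` at 30.2 10^-6 cm/s while compound 3 `N#C[C@H]1C[C@@H]1CN([C@H](CCC(F)(F)F)C(N)=O)S(=O)(=O)c1ccc(Cl)cc1` gives 21.5 10^-6 cm/s so compound 3 lies within the scatter of both others.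

Within the data shown here, still unmeasured, compound 4 `C[C@]1(C#N)C[C@H](CN([C@H](CCC(F)(F)F)C(N)=O)S(=O)(=O)c2ccc(Cl)cc2)C1` carries 3-cyano-3-methylcyclobutyl in place of 2-cyanocyclopropyl on a saturated chain carbon bound to a sulfonamide nitrogen and no measured compound carries that group itself.

Among the measured compounds shown here, the closest precedent shows a 1.4-fold lower number from compound 2 to compound 3 (0.15 log units; within the scatter) for another exchange between two cyano-bearing groups at this place. The two steps that remove 1,2,4-oxadiazol-3-yl show a 1.6-fold higher number from compound 1 to compound 2 (0.19 log units; within the scatter) and a 1.1-fold higher number from compound 1 to compound 3 (0.05 log units; within the scatter) so none of the three measured steps leaves the scatter. With so few compounds this is thin evidence, but it gives no ground for expecting a large move or for choosing a firm direction.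

The expected outcome in this assay is a 1.1-fold higher number from compound 3 to compound 4 (0.05 log units; within the scatter) and thus no step beyond the scatter. For compound 4 the estimate is 24 10^-6 cm/s with an expected range from 13 10^-6 cm/s to 42 10^-6 cm/s for this read-out.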

Compound 4, apparent permeability: 21.8 10^-6 cm/s
Compound 4: the middle estimate sits 1.1-fold (0.04 log units) above what was measured; the range from low to high includes it.
By their numbers in this assay, from the lowest: compounds 1, 3, 4 and 2 (each within the scatter of the next).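

In this assay, 3-cyano-3-methylcyclobutyl in place of 2-cyanocyclopropyl on a saturated chain carbon bound to a sulfonamide nitrogen gives a 1.0-fold higher number from compound 3 to compound 4 (0.01 log units; within the scatter), so the exchange of the three-membered ring for the four-membered ring, with the added methyl, leaves the read-out within the scatter. The other two comparisons at this place agree, with a 1.4-fold lower number from compound 2 to compound 4 (0.14 log units; within the scatter) and a 1.1-fold higher number from compound 1 to compound 4 (0.05 log units; within the scatter), which means that all four groups now shown at this place, three of them cyano-bearing and one carrying 1,2,4-oxadiazol-3-yl, give numbers within the scatter of one another wherever a step is printed. Nothing at hand speaks to why the read-out stays flat at this place.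

All four groups carry either a nitrile or a 1,2,4-oxadiazole, so the compounds shown leave open whether a primary amine or a carboxylic acid in that role would give a step beyond the scatter. Also open, going by these compounds, is whether a plain longer chain such as n-hexyl, with no ring and no nitrile, at this same place would keep the read-out within the scatter of these four compounds.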